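The compounds below may be only part of what the source reports. "The series", "measured", "known", "first", "only" and "open" are said of these compounds alone.

In an ADME assay on HEK-293T cells (Homo sapiens) for cytotoxicity, with a stated time of 48 h (a higher number here means that more compound is tolerated, a lower number that less compound is tolerated), compound 1 `CCc1ncnc(NC(C)c2cc3cccc(OC)c3o2)c1Cl` gives a value that is only a limit of the assay, > 10000 nM. Compound 2 `CCC(Nc1cc(C)ncn1)c1ccc(Oc2ccc(F)cc2)cc1` also reaches only a limit in this assay, > 10000 nM. Compound 2 therefore stands at the limit of > 10000 nM in this assay, at which 2 of the 2 values shown sit. Compound 3 `CCCc1cc(NC(CC)c2ccc(Oc3ccc(F)cc3)cc2)ncn1` differs from compound 2 by ethyl in place of hydrogen on a saturated chain carbon bound to an aromatic carbon. Among the compounds with values here, no measured pair here shows what such a change does, so no step beyond the usual scatter in this assay is expected from compound 2 to compound 3. Compound 3 is estimated to give 15000 nM in this assay, with a range from 7000 nM to 30000 nM, and the expected step is a step that the limit leaves unreadable from compound 2 to compound 3.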

Compound 3, half-maximal cytotoxic concentration: > 10000 nM
Compound 3: no number, only a limit; the forecaster's own chance of this, stated with the estimate: 85%; the middle value does not contradict the limit.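

Within the data shown here, compound 3 also gives only a limit of the assay in this assay (> 10000 nM), so no step from compound 2 to compound 3 can be read. Going by these compounds, what ethyl in place of hydrogen does to the tolerated concentration stays open.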